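The source may report more compounds than this note shows. Statements on the series, on what has been measured and on what is new or still open speak of the compounds shown alone.

Compound 1 `Cc1ccc2nc(C(=O)Nc3c(F)cc(-c4cccc(F)c4)cc3F)c(C)c(O)c2c1` serves as the starting point. In a functional assay on Hep 3B2 cells (Homo sapiens) for antiproliferative activity, read by MTT assay, with a stated time of 24 h, tested at 100 ug/mL (a lower number here means a weaker effect, a higher number a stronger effect of the compound at the concentration tested), compound 1 gives 68.3%. Compound 2 `CCc1ccc2nc(C(=O)Nc3c(F)cc(-c4cccc(F)c4)cc3F)c(C)c(O)c2c1` differs from it only in carrying a methyl in place of hydrogen on a saturated chain carbon bound to an aromatic carbon, and in this assay compound 2 gives 63.2%. The change from compound 1 to compound 2 amounts to a number 5.1 percentage points lower from compound 1 to compound 2 (within the scatter). Among the compounds with values here, compound 2 therefore stands together with compound 1, its only neighbour among the measured compounds, and the two cannot be told apart within the scatter.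

Compound 3 `Cc1c(C(=O)Nc2c(F)cc(-c3cccc(F)c3)cc2F)nc2ccc(F)cc2c1O` is the next compound in this series. It is built from compound 2 by the change (fluoro in place of ethyl on an aromatic carbon). Within the data shown here, no measured step addresses an exchange of this kind on an aromatic carbon; the single measured step, a number 5.1 percentage points lower from compound 1 to compound 2 (within the scatter), concerns a different place and lies within the scatter. With nothing in the measured data pointing to a shift in either direction, compound 3 is expected to give about 64% in this assay, between 48% and 80%, that is a step of a number 0.8 percentage points higher from compound 2 to compound 3 (within the scatter) from compound 2.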

Compound 3, a percentage reported as inhibition, at one concentration (the size of the read-out at that concentration, not a potency): 75.2%
Estimate against measurement, compound 3: 11.2 percentage points below, within the range that was stated.
By their numbers in this assay, from the lowest: compounds 2, 1 and 3 (each within the scatter of the next, the first and the last beyond it).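

Within the data shown here, at its place on an aromatic carbon of a six-membered aromatic ring of carbon only, part of a fused or bridged system of two rings, the exchange of ethyl for fluoro gives the first step in this assay that clears the scatter, a modest one: a number 12 percentage points higher from compound 2 to compound 3 (beyond the scatter). The exchange of methyl for fluoro at the same place gives a number 6.9 percentage points higher from compound 1 to compound 3 (within the scatter), so fluoro and methyl cannot be told apart here, and only the two ends of the series, ethyl and fluoro, are separated. The data at hand offer nothing that accounts for this difference.

From the compounds shown here alone, what a chlorine, a methoxy group or an amine would give at this place remains open, as does whether a longer chain such as propyl would fall in line with ethyl or differ from it. Going by these compounds, because each read-out is the size of the effect at one concentration, how these compounds compare in potency also remains open.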